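The source may report more compounds than this note shows. Statements on the series, on what has been measured and on what is new or still open speak of the compounds shown alone.

Series notes. Compound 1 `OC[C@H]1O[C@H](Oc2ccc(-n3ccc4ccccc43)cc2F)[C@@H](O)[C@@H](O)[C@@H]1O`, compound 2 `O=[N+]([O-])c1ccc2c(ccn2-c2ccc(O[C@H]3O[C@H](CO)[C@@H](O)[C@H](O)[C@@H]3O)c(F)c2)c1` and compound 3 `O=[N+]([O-])c1ccc2c(c1)CCN2c1ccc(O[C@H]2O[C@H](CO)[C@@H](O)[C@H](O)[C@@H]2O)c(Cl)c1` have been measured in an ADME assay on a cell-free system (plasma, Homo sapiens) for protein binding, read by LC-MS, with a stated time of 5 h, tested at 10 uM. In this assay compound 1 gives 98%, compound 2 gives 95% and compound 3 gives 99%, the lowest unbound fraction of the three; its gap to compound 2 lies beyond the scatter, while its gap to compound 1 stays within the scatter, so compound 1 and compound 3 cannot be ordered on these data.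

Compound 4 `OC[C@H]1O[C@H](Oc2ccc(N3CCc4ccccc43)cc2Cl)[C@@H](O)[C@@H](O)[C@@H]1O` has not yet been measured in this assay. The difference between the core of compound 3 and the core of compound 2 is not broken down here. Compound 4 stands to compound 3 as compound 1 stands to compound 2. The measured pair differs by hydrogen in place of nitro on an aromatic carbon, and that change gave a 2.5-fold lower unbound fraction from compound 2 to compound 1 (0.40 log units; beyond the scatter). The unmeasured pair differs by hydrogen in place of nitro on an aromatic carbon, the same change at the same place, which therefore occurs twice among these compounds.

For the measured compounds named here, the only precedent for the change is the step from compound 2 to compound 1, and compound 3 already starts from 99%, so little room remains in the unbound fraction. A step of about the size of the measured one is expected from compound 3 to compound 4, namely a 2.5-fold lower unbound fraction from compound 3 to compound 4 (0.40 log units; beyond the scatter), because the precedent is a 2.5-fold lower unbound fraction from compound 2 to compound 1 (0.40 log units; beyond the scatter). Compound 4 is therefore expected to give 99.6% in this assay, within an expected range of 99% to 99.9%, with a real chance that the assay reports only a limit.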

Compound 4, plasma protein binding in the plasma assay: 99%
Beside the measured number, compound 4's estimate is 2.5-fold (0.40 log units) (unbound fraction) below it, within the range that was stated.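

In the plasma assay compound 3 gives 99% and compound 4 gives 99%. In the plasma assay, replacing nitro with hydrogen gives no change at the digits printed from compound 3 to compound 4 (within the scatter), and set beside the earlier step, the result on the two cores does not differ beyond the scatter: the same change on two cores in the plasma assay, a 2.5-fold lower unbound fraction (0.40 log units; beyond the scatter) from compound 2 to compound 1 and no change at the digits printed (within the scatter) from compound 3 to compound 4, 2.5-fold (0.40 log units) apart, within the scatter of two such steps. For the compounds shown here, the change can therefore be carried from one core to the other without a detectable difference in this read-out, but a shared step size is not established: only two cores are available, and the step is beyond the scatter on one and within it on the other. In a physicochemical assay for solubility, using the shake flask method, measured as thermodynamic solubility, with a stated time of 2 h, at pH 6.5 (on this read-out higher numbers stand for higher solubility and lower numbers for lower solubility), compound 3 gives 3.6 ug/mL and compound 4 gives 21 ug/mL. In the physicochemical assay, the same change gives a 5.8-fold higher number from compound 3 to compound 4 (0.77 log units; beyond the scatter), but this step is available on one core only, so the compounds shown offer no second core against which to compare it.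

The compounds shown leave open whether the plasma protein binding step would hold on a third core and whether the solubility step would recur on any other core. They also leave open how both read-outs respond to groups other than nitro and hydrogen on the same aromatic carbon, for example an amine or a carboxylic acid.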